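Swapping the Ring on the Sulfonamide Nitrogen

The source may report more compounds than this note shows. Statements on the series, on what has been measured and on what is new or still open speak of the compounds shown alone.

Compound 1 `Cc1cc(C)nc(NS(=O)(=O)c2ccc(/N=C/c3c(Cl)c4cc(C(C)(C)C)cc(C(C)(C)C)c4oc3=O)cc2)n1`: 220 nM
Compound 2 `Cc1cc(NS(=O)(=O)c2ccc(/N=C/c3c(Cl)c4cc(C(C)(C)C)cc(C(C)(C)C)c4oc3=O)cc2)no1`: 240 nM

In a functional assay on B16-F10 cells (Mus musculus) for cytotoxicity, read by CCK-8 assay, with a stated time of 48 h (on this read-out lower numbers stand for stronger inhibition and higher numbers for weaker inhibition), compound 2 gives the higher of the two numbers, but the step of a 1.1-fold higher number from compound 1 to compound 2 (0.04 log units; within the scatter) lies within the scatter, so the two compounds are not distinguishable. Compound 3 `Cc1ccnc(NS(=O)(=O)c2ccc(/N=C/c3c(Cl)c4cc(C(C)(C)C)cc(C(C)(C)C)c4oc3=O)cc2)n1` differs from compound 2 by 4-methylpyrimidin-2-yl in place of 5-methyl-1,2-oxazol-3-yl on a sulfonamide nitrogen. Going by the values given here, the only measured step bearing on such an exchange of ring on the sulfonamide nitrogen, a 1.1-fold higher number from compound 1 to compound 2 (0.04 log units; within the scatter), left the number essentially unchanged. Because compound 1 gives 220 nM with a closely related ring, compound 3 is expected to show a step of a 1.0-fold lower number from compound 2 to compound 3 (0.02 log units; within the scatter) that stays within the scatter. Compound 3 is estimated at 230 nM, within 110 nM to 470 nM.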

Compound 3, half-maximal inhibitory concentration: 190 nM
Compound 3: the middle estimate sits 1.2-fold (0.08 log units) above what was measured; the measured number falls inside the stated range.
By their numbers in this assay, from the lowest: compounds 3, 1 and 2 (each within the scatter of the next).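

In this assay, a third ring on the sulfonamide nitrogen, 4-methylpyrimidin-2-yl, also leaves the number within the scatter (a 1.3-fold lower number from compound 2 to compound 3 (0.10 log units; within the scatter)). The new compound also tests a single methyl on the pyrimidine ring: hydrogen in its place gives a step that is likewise within the scatter (a 1.2-fold lower number from compound 1 to compound 3 (0.06 log units; within the scatter)). Nothing given here explains why these exchanges leave the numbers so close.

The compounds shown leave open whether a ring is needed at all on this nitrogen. A plain methyl there, or a ring carrying a carboxylic acid or an amine, could give a different number.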